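Swapping the basic ring on a propyl chain

A few compounds are considered here, and "the series" means these few. Any claim that something is new, unique, unknown or untested is made for them only; others in the source may bear on it.

Measured compounds:
- Compound 1, `O=C1c2c[n+]([O-])c3ccccc3c2C(=O)c2c1c1ccccc1n2CCCCN1CCNCC1`: 540 nM
- Compound 2, `O=C1c2c[n+]([O-])c3ccccc3c2C(=O)c2c1c1ccccc1n2CCN1CCCC1`: 410 nM
- Compound 3, `CN1CCN(CCCn2c3c(c4ccccc42)C(=O)c2c[n+]([O-])c4ccccc4c2C3=O)CC1`: 140 nM

These three compounds were tested in a functional assay on A549 cells (Homo sapiens) for cytotoxicity, read by MTT assay, with a stated time of 72 h; a lower number here means a stronger inhibitor, a higher number a weaker inhibitor. Compound 3 has the lowest number of the three: the step of a 2.9-fold lower number from compound 2 to compound 3 (0.47 log units; beyond the scatter) and the step of a 3.9-fold lower number from compound 1 to compound 3 (0.59 log units; beyond the scatter) both lie beyond the scatter, so compound 3 is the strongest of the measured set.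

Compound 4, `O=C1c2c[n+]([O-])c3ccccc3c2C(=O)c2c1c1ccccc1n2CCCN1CCC(O)CC1`, is made from compound 3 by one change: 4-hydroxypiperidin-1-yl in place of 4-methylpiperazin-1-yl on a saturated chain carbon, three bonds along the chain from an aromatic nitrogen. Among the measured compounds shown here, no measured pair shows exactly this swap. What the measured steps do show is that changing the group at the end of the chain moves the number by a modest amount in either direction, as in a 1.3-fold lower number from compound 1 to compound 2 (0.12 log units; within the scatter), a 3.9-fold lower number from compound 1 to compound 3 (0.59 log units; beyond the scatter) and a 2.9-fold lower number from compound 2 to compound 3 (0.47 log units; beyond the scatter). In this assay the change to compound 4 is therefore expected to give a modest step, most likely toward a higher number, a 2.1-fold higher number from compound 3 to compound 4 (0.33 log units; beyond the scatter). The estimated value for compound 4 is 300 nM, within a range from 100 nM to 900 nM.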

Compound 4, half-maximal inhibitory concentration: 350 nM
Beside the measured number, compound 4's estimate is 1.2-fold (0.07 log units) below it; the range from low to high includes it.
By their numbers in this assay, from the lowest: compound 3; then compounds 4, 2 and 1 (each within the scatter of the next).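

In this assay, the swap on the propyl chain gives a 2.5-fold higher number from compound 3 to compound 4 (0.40 log units; beyond the scatter), so exchanging 4-methylpiperazin-1-yl for 4-hydroxypiperidin-1-yl, another six-membered non-aromatic ring with the same number of heavy atoms, is enough to move the number beyond the scatter. The other comparisons, a 1.2-fold lower number from compound 2 to compound 4 (0.07 log units; within the scatter) and a 1.5-fold lower number from compound 1 to compound 4 (0.19 log units; within the scatter), lie within the scatter, so compound 4 cannot be told apart from compound 1 or compound 2, and compound 3 alone stands apart as the strongest of the four. No supporting evidence explains this step.

The compounds shown leave open whether the step follows the hydroxy group or the replaced ring nitrogen. A 4-methylpiperidin-1-yl group on the same propyl chain would separate those two changes, and a butyl chain carrying 4-methylpiperazin-1-yl would test the chain length.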